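Swapping Fluoro for Methoxy in a Small Series

The compounds below may be only part of what the source reports. "The series", "measured", "known", "first", "only" and "open" are said of these compounds alone.

Among the measured compounds shown here, in a functional assay on HL-60 cells (Homo sapiens) for inhibition, read by MTT assay, with a stated time of 72 h (on this read-out lower numbers stand for stronger inhibition and higher numbers for weaker inhibition), compound 3 (`Cc1nc(-c2cccc(F)c2)c(C(=O)N2CCN(c3cccc(Cl)c3)CC2)o1`) gives 33.7 nM, the only number in this set. Compound 1 (`COc1ccc(-c2nc(C)oc2C(=O)N2CCN(c3cccc(Cl)c3)CC2)cc1OC`) is recorded as "not active" (no number reported). Compound 2 (`O=C(c1oc(C(F)(F)F)nc1-c1cccc(F)c1)N1CCN(c2cccc(Cl)c2)CC1`) is recorded as "not active" (no number reported). Compound 3 therefore has no second number to be ranked against, and the two compounds without a number cannot be placed on the scale.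

Compound 4 (`COc1cccc(-c2nc(C)oc2C(=O)N2CCN(c3cccc(Cl)c3)CC2)c1`) has not yet been measured. It comes from compound 3 by one change, methoxy in place of fluoro on an aromatic carbon, 3-fluorophenyl to 3-methoxyphenyl: methoxy in place of fluoro on an aromatic carbon. For the measured compounds named here, no measured step between two compounds is available as a guide. Going by the values given here, the only hint is compound 1, which also carries methoxy and is recorded as "not active" (no number reported). That is one compound, and it is weak evidence.

The expected step of a 4.5-fold higher number from compound 3 to compound 4 (0.65 log units; beyond the scatter) in this assay is towards weaker inhibition and beyond the usual scatter. Compound 4 is estimated at 150 nM, with an expected range of 25 nM to 1500 nM.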

Compound 4, half-maximal inhibitory concentration: "not active" (no number reported)
For compound 4 the study gives words and no number; no gap can be computed for the estimate.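

Among the compounds shown here, compound 4, like compounds 1 and 2, is recorded in words only in this assay, so no step from compound 3 to compound 4 can be read. No evidence shown bears on this result. The compounds shown leave open how much weaker compound 4 is than compound 3, if it differs at all.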